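Xanthine series: benzyl variation at the pyrazole nitrogen

This account rests on a few compounds, and the source may have more. Where it says the series, first, only, none or still open, it means among the compounds named here.

Among the measured compounds shown here, compound 1 `CCCn1c(=O)c2nc(-c3cnn(Cc4cc(Cl)ccc4Cl)c3)[nH]c2n(CCC)c1=O` is the only member with a number: in an assay on CHO cells for displacement of a labelled ligand from adenosine receptor A1 (Homo sapiens) (a higher number here means a weaker inhibitor, a lower number a stronger inhibitor), compound 1 gives 190 nM. Compound 2 `CCCn1c(=O)c2nc(-c3cnn(Cc4ccc(F)cc4F)c3)[nH]c2n(CCC)c1=O` has no result in this assay, where compound 2 is reported as "not determined" (no result reported), so it stands nowhere on the numbers, and the step from compound 2 to compound 3 cannot be given a direction from data. Compound 3 `CCCn1c(=O)c2nc(-c3cnn(Cc4cc(C(F)(F)F)ccc4Cl)c3)[nH]c2n(CCC)c1=O` carries 2-chloro-5-(trifluoromethyl)phenyl in place of 2,4-difluorophenyl on a saturated chain carbon bound to an aromatic nitrogen. With compound 2 undetermined, no step size beyond the scatter is claimed for the change in this assay. Compound 3 is expected near 150 nM, within 40 nM to 600 nM, because compound 1 gives 190 nM with a related benzyl group.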

Compound 3, inhibition constant: 1200 nM
Compound 3: middle estimate off by 8.0-fold (0.90 log units), on the low side; measured number above the stated range.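

With trifluoromethyl in place of chloro on an aromatic carbon, this assay gives a 6.3-fold higher number from compound 1 to compound 3 (0.80 log units; beyond the scatter). This first readable step shows that the number responds to a single substituent change on the benzyl ring, with the chain carbon and the shared core held constant. Nothing at hand accounts for the rise.

Steps involving compound 2 cannot be read, so 2,4-difluorophenyl remains unplaced against the other two rings. From the compounds shown here alone, whether a methyl or methoxy group in place of trifluoromethyl would behave like chloro also stays open.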